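From 2-Bromobenzyl to 2,4-Dichlorobenzyl at the Assay Limit

This account rests on a few compounds, and the source may have more. Where it says the series, first, only, none or still open, it means among the compounds named here.

Compound 2 `OC[C@H]1O[C@@H](n2cnc3c(NCc4ccccc4Br)ncnc32)[C@H](O)[C@@H]1O` gives > 166000 nM in a functional assay on B16 cells (Mus musculus) for antiproliferative activity, with a stated time of 72 h (on this read-out higher numbers stand for weaker inhibition and lower numbers for stronger inhibition), which is a limit and not a number. Compound 3 `COc1ccccc1CNc1ncnc2c1ncn2[C@@H]1O[C@H](CO)[C@@H](O)[C@H]1O` gives > 166000 nM in this assay, which is also a limit. Compound 1 `OC[C@H]1O[C@@H](n2cnc3c(NCc4cccc(F)c4)ncnc32)[C@H](O)[C@@H]1O` is recorded as "not determined" (no result reported) in this assay. Compound 2 therefore has no exact value, and the measured series consists of the limit of > 166000 nM in this assay, at which 2 of the 3 values shown sit.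

Compound 4 `OC[C@H]1O[C@@H](n2cnc3c(NCc4ccc(Cl)cc4Cl)ncnc32)[C@H](O)[C@@H]1O` has 2,4-dichlorophenyl in place of 2-bromophenyl on a saturated chain carbon bound to a nitrogen on an aromatic ring. Among the measured compounds shown here, only one measured step bears on this change, a step that the two limits leave unreadable from compound 2 to compound 3, and it offers no size to carry over. For the measured compounds named here, with that step as the only guide, no change beyond the scatter is expected in this assay, in either direction. The expected step is a step that the limit leaves unreadable from compound 2 to compound 4. Another limit is the likeliest report. Should a number appear, the estimate for compound 4 is 170000 nM, with an expected range from 60000 nM to 350000 nM.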

Compound 4, half-maximal inhibitory concentration: > 166000 nM
Compound 4 ended at the assay's limit; the forecaster's own chance of this, stated with the estimate: 80%; the middle value lies beyond the limit too.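

Compound 4 gives > 166000 nM in this assay, which is a limit and not a number, so its steps from compound 2 and compound 3 cannot be read. The compounds shown leave open whether changing the substituted benzyl group shifts the activity at all, and in which direction.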